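A methoxyphenyl amide exchanged for a bromophenyl amide

This account rests on a few compounds, and the source may have more. Where it says the series, first, only, none or still open, it means among the compounds named here.

Among the measured compounds shown here, in an ADME assay on HepG2 cells (Homo sapiens) for cytotoxicity, read by trypan blue exclusion, with a stated time of 48 h, in the presence of a further agent that is not named here (on this read-out higher numbers stand for lower toxicity in this test and lower numbers for higher toxicity in this test), compound 1 `COc1cccc(NC(=O)COc2cc(C)nc3ccc(OC)cc23)c1` gives 24700 nM, the only plain number among the three measured compounds. Compound 2 `COc1ccc2nc(C)cc(OCC(=O)Nc3ccc(OC)c(OC)c3)c2c1` reaches only a limit of the assay, > 131000 nM. Compound 3 `COc1cc(NC(=O)COc2cc(C)nc3ccc(OC)cc23)cc(OC)c1` likewise reaches only a limit, > 131000 nM. Both steps, an at least 5.3-fold higher number from compound 1 to compound 2 (0.72 log units; beyond the scatter) and an at least 5.3-fold higher number from compound 1 to compound 3 (0.72 log units; beyond the scatter), run toward lower toxicity and are bounded by the limit of > 131000 nM in this assay, at which 2 of the 3 values shown sit. Compound 4 `COc1ccc2nc(C)cc(OCC(=O)Nc3ccc(Br)cc3)c2c1` differs from compound 1 by 4-bromophenyl in place of 3-methoxyphenyl on an amide-type nitrogen. For the measured compounds named here, no measured step covers this exchange; the two measured steps add a methoxy rather than swap the aryl group, so they bear on it only loosely. The step of a 1.8-fold higher number from compound 1 to compound 4 (0.26 log units; within the scatter) is therefore expected to be modest at most. The estimate for compound 4 in this assay is 45000 nM, between 12000 nM and 131000 nM.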

Compound 4, half-maximal cytotoxic concentration: > 125000 nM
Compound 4: only a limit was reported (the forecaster's own chance of this, stated with the estimate: 35%); middle value at least 2.7-fold (0.44 log units) from the limit.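

In this assay, the exchange on the amide-type nitrogen gives an at least 5.0-fold higher number from compound 1 to compound 4 (0.70 log units; beyond the scatter). The earlier compounds shown here showed this direction only when a methoxy was added; here it also appears when the methoxy leaves and 4-bromophenyl enters. The size of the step remains bounded because compound 4 reaches only a limit: the limit of > 125000 nM in this assay, at which 1 of the 4 values shown sits.

The compounds shown leave open whether the number depends on bromine itself or simply on the loss of the 3-methoxyphenyl group. They also leave open how an aryl group bearing an amine or a carboxylic acid would behave at this place.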